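Trading a Nitro Group for Hydrogen

The compounds below may be only part of what the source reports. "The series", "measured", "known", "first", "only" and "open" are said of these compounds alone.

Among the measured compounds shown here, in a functional assay on L1210 cells (Mus musculus) for antiproliferative activity, read by MTT assay, with a stated time of 72 h (on this read-out higher numbers stand for weaker inhibition and lower numbers for stronger inhibition), compound 1 `COc1ccc(C2=NN(C(C)=O)C(c3ccc([N+](=O)[O-])cc3)O2)cc1` gives 68000 nM, the only true number available so far. Compound 2 `COc1ccc(C2=NN(C(C)=O)C(c3ccc(OC)c([N+](=O)[O-])c3)O2)cc1` is recorded at > 100000 nM, and this is a limit of this assay, not a number.

Compound 3 `COc1ccc(C2=NN(C(C)=O)C(c3ccc(OC)cc3)O2)cc1` has not yet been measured. It differs from compound 2 in one place, with hydrogen in place of nitro on an aromatic carbon. That carbon lies ortho to a methoxy group and meta to a large group, and the rest of the structure stays the same.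

For the measured compounds named here, no measured pair shows what this kind of change does, so any expectation here is loose. The one numeric result, compound 1 at 68000 nM, is a weak inhibition, so only a modest move in this assay is expected. Compound 3 may also end at a limit. The expected change is an at least 1.4-fold lower number from compound 2 to compound 3 (0.15 log units; that floor lies within the scatter), a small one toward stronger inhibition. For compound 3 the estimated value is 70000 nM, with an expected range from 30000 nM to 100000 nM.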

Compound 3, half-maximal inhibitory concentration: > 100000 nM
Compound 3 was reported as a limit (the forecaster's own chance of this, stated with the estimate: 40%); middle value at least 1.4-fold (0.15 log units) from the limit.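

Taking the nitro group off this aromatic carbon, ortho to a methoxy group, still gives no true number in this assay, since the result for compound 3 is a limit, just as the result for compound 2 is. The step between these two compounds cannot be read, because both sit at the same limit: the limit of > 100000 nM in this assay, at which 2 of the 3 values shown sit. Among the compounds shown here, the one readable step, with methoxy in place of nitro on an aromatic carbon, is an at least 1.4-fold higher number from compound 1 to compound 3 (0.16 log units; that floor lies within the scatter), so this comparison does not establish a real loss of inhibition, although it gives the first sign of how a change from nitro to methoxy may read.

From the compounds shown here alone, how far hydrogen and nitro on this carbon differ in their effect on these cells remains unknown, as any difference lies beyond what this limit can show. The compounds shown also do not tell whether an amine or a carboxylic acid on this carbon would bring the value within the range of this assay.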